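Swapping a thiophene for a methylpyrazole on the amine arm

The source may hold more compounds than are shown below. What is called first, only, known or untested is meant among the compounds shown, and "the series" means these compounds.

Compound 1, whose structure is `C[C@H]1[C@H](NCc2ccsc2)C[C@H]2C[C@@H]1C2(C)C`, is one of three compounds tested in an ADME assay on MDCK cells (Canis lupus familiaris) for cytotoxicity, read by microscopy, with a stated time of 48 h; a higher number here means that more compound is tolerated, a lower number that less compound is tolerated. In that assay compound 1 gives 50000 nM, the highest of the three numbers. Its nearest neighbour is compound 2, `C[C@H]1[C@H](NCc2cc(-c3ccsc3)cs2)C[C@H]2C[C@@H]1C2(C)C`, which gives 25000 nM; the two numbers lie within the usual scatter, so no order between them can be claimed. Furthest away is compound 3, `C[C@H]1[C@H](NCc2cc(C3CCCCC3)cs2)C[C@H]2C[C@@H]1C2(C)C`, which gives 780 nM. The only single-point step among these is a 32-fold lower number from compound 2 to compound 3 (1.51 log units; beyond the scatter).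

The unmeasured compound 4 has the structure `Cc1n[nH]cc1CN[C@@H]1C[C@H]2C[C@@H]([C@H]1C)C2(C)C`. It differs from compound 1 in one place: 3-methyl-1H-pyrazol-4-yl in place of thiophen-3-yl on a saturated chain carbon bound to an amine nitrogen.

Among the measured compounds shown here, no measured step changes the group on the saturated chain carbon bound to an amine nitrogen, so nothing directly matches this change. For the measured compounds named here, the one measured step replaces thiophen-3-yl with cyclohexyl on an aromatic carbon, a different place and a different entering group. Compound 1 and compound 2 show that adding a second thiophene leaves the number within the scatter. On this thin basis, compound 4 is expected to stay close to compound 1, with an expected step of no change at the digits printed from compound 1 to compound 4 (within the scatter) in this assay. The estimate for compound 4 is therefore 50000 nM, within a range from 20000 nM to 100000 nM.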

Compound 4, minimum cytotoxic concentration: > 100000 nM
Compound 4 was reported as a limit; the forecaster's own chance of this, stated with the estimate: 20%; at least 2.0-fold (0.30 log units) between middle value and limit.
By their numbers in this assay, from the lowest: compound 3; then compounds 2 and 1 (each within the scatter of the next). At a limit, above all of these: compound 4.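

In this assay, compound 4 gives > 100000 nM, which is a limit of the assay and not a number. Among the compounds shown here, this is the first change measured on the saturated chain carbon bound to an amine nitrogen, and 3-methyl-1H-pyrazol-4-yl in place of thiophen-3-yl there gives an at least 2.0-fold higher number from compound 1 to compound 4 (0.30 log units; that floor lies within the scatter), so the change brings no detectable loss of tolerance, while the true size of the step remains unknown. Compound 4 is the only compound shown that reaches this limit: the limit of > 100000 nM in this assay, at which 1 of the 4 values shown sits.

From the compounds shown here alone, it remains open whether a phenyl ring or a pyrazole without the methyl group would give the same reading on this carbon. Also open, going by these compounds, is whether a cyclohexyl group, which goes with the lowest number when carried on the thiophene of compound 3, would lower the number of compound 4 in this assay.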